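Moving the iodine on one ring of compound 3

The source may hold more compounds than are shown below. What is called first, only, known or untested is meant among the compounds shown, and "the series" means these compounds.

Of the compounds shown here, three sharing one core have been measured in an assay on cells for agonist activity at ecdysone receptor (Bombyx mori), read by a luciferase reporter, with a stated time of 24 h; on this read-out higher numbers stand for an effect only at larger amounts of compound and lower numbers for an effect already at smaller amounts. Compound 1 `Cc1ccccc1C(=O)N(NC(=O)c1ccccc1)C(C)(C)C` gives 224 nM. Compound 2 `Cc1cc(C)cc(C(=O)N(NC(=O)c2ccccc2)C(C)(C)C)c1` gives 69.2 nM. Compound 3 `CC(C)(C)N(NC(=O)c1ccccc1I)C(=O)c1ccccc1Cl` gives 1290 nM, the highest of the three numbers, higher than both compound 1 and compound 2 by gaps beyond the usual scatter.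

Compound 4 `CC(C)(C)N(NC(=O)c1ccc(I)cc1)C(=O)c1ccccc1Cl` is not yet measured. It differs from compound 3 in one place: 4-iodophenyl in place of 2-iodophenyl on a carbonyl carbon. The ring keeps its single iodine, but the iodine now sits on the 4-iodophenyl pattern rather than the 2-iodophenyl pattern, on the carbonyl carbon that is joined to the amide-type nitrogen.

For the measured compounds named here, only one measured step is available, a 3.2-fold lower number from compound 1 to compound 2 (0.51 log units; beyond the scatter), and it concerns the other carbonyl carbon of the core, with a different ring substituent pattern. It shows that changing where groups sit on a ring can move the read-out by a modest amount, but it does not test the 2-iodophenyl to 4-iodophenyl change itself. With that thin basis, compound 4 is expected to give a somewhat lower number, an estimated step of a 4.3-fold lower number from compound 3 to compound 4 (0.63 log units; beyond the scatter). Compound 4 is expected to come in around 300 nM, within a range from 60 nM to 1500 nM.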

Compound 4, half-maximal effective concentration: 7.59 nM
Compound 4: middle estimate off by 40-fold (1.60 log units), on the high side; the whole stated range lies above it.
By their numbers in this assay, from the lowest: compound 4; then compound 2; then compound 1; then compound 3.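

In this assay, moving the single iodine on this ring from the 2-iodophenyl to the 4-iodophenyl pattern gives a 170-fold lower number from compound 3 to compound 4 (2.23 log units; beyond the scatter) and so reveals a large sensitivity at this carbonyl carbon. For the compounds shown here, the two compounds have the same atoms joined differently, so the placing of one iodine is the only change, and the sole earlier step, a 3.2-fold lower number from compound 1 to compound 2 (0.51 log units; beyond the scatter), was much smaller and concerned the other carbonyl carbon. No measurement shown here explains why the position of the iodine matters so much.

From the compounds shown here alone, it remains open whether another group on the ring in place of the iodine, such as a methoxy group, a nitrile or an amine, would keep a number this low. Going by these compounds, it is also open whether the same shift of the iodine would have a similar effect with a different ring on the other carbonyl carbon, such as the 3,5-dimethylphenyl ring of compound 2.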